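The source may report more compounds than this note shows. Statements on the series, on what has been measured and on what is new or still open speak of the compounds shown alone.

Measured compounds in a functional assay on K562 cells (Homo sapiens) for antiproliferative activity, with a stated time of 72 h; on this read-out higher numbers stand for weaker inhibition and lower numbers for stronger inhibition:

Compound 1 `OC[C@H]1O[C@@H](n2cnc3c(NCc4ccc(Br)cc4)ncnc32)[C@H](O)[C@@H]1O` gives 68200 nM.
Compound 2 `Cc1ccc(CNc2ncnc3c2ncn3[C@@H]2O[C@H](CO)[C@@H](O)[C@H]2O)cc1` reaches only a limit of the assay, > 166000 nM.
Compound 3 `OC[C@H]1O[C@@H](n2cnc3c(NCc4ccc(Cl)cc4Cl)ncnc32)[C@H](O)[C@@H]1O` gives 106000 nM.

Compound 1 stands lowest of the two numbers that were obtained, and its nearest neighbour is compound 3, with a 1.6-fold higher number from compound 1 to compound 3 (0.19 log units; within the scatter). Compound 2 sits at the limit of > 166000 nM in this assay, at which 1 of the 3 values shown sits. The step from compound 1 to compound 4 `OC[C@H]1O[C@@H](n2cnc3c(NCc4cccc(C(F)(F)F)c4)ncnc32)[C@H](O)[C@@H]1O` is 3-(trifluoromethyl)phenyl in place of 4-bromophenyl on a saturated chain carbon bound to a nitrogen on an aromatic ring. Within the data shown here, two measured steps bear on it. The aryl swap a 1.6-fold higher number from compound 1 to compound 3 (0.19 log units; within the scatter) changed little, and an at least 1.5-fold lower number from compound 2 to compound 3 (0.19 log units; that floor lies within the scatter) likewise stayed within the scatter. Only an at least 2.4-fold higher number from compound 1 to compound 2 (0.38 log units; beyond the scatter) moved clearly, and that exchange runs in the opposite sense to a halogen-bearing ring being kept. On these grounds no step beyond the scatter is expected in this assay for compound 4, perhaps a slight rise. Compound 4 is therefore estimated at 85000 nM, between 35000 nM and 200000 nM, meaning an expected 1.2-fold higher number from compound 1 to compound 4 (0.10 log units; within the scatter).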

Compound 4, half-maximal inhibitory concentration: > 166000 nM
Compound 4 ended at the assay's limit; the forecaster's own chance of this, stated with the estimate: 20%; middle value at least 1.9-fold (0.29 log units) from the limit.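

In this assay, replacing the 4-bromophenyl group on this saturated chain carbon with 3-(trifluoromethyl)phenyl gives an at least 2.4-fold higher number from compound 1 to compound 4 (0.38 log units; beyond the scatter), so a second exchange of that ring, besides the one to 4-methylphenyl, now moves the number clearly. Among these compounds, the other readable step, an at least 1.5-fold higher number from compound 3 to compound 4 (0.19 log units; that floor lies within the scatter), has a floor that stays within the scatter, so it fixes no order for that pair. Compound 2 and compound 4 both end at a limit, so the step between them cannot be read: the limit of > 166000 nM in this assay, at which 2 of the 4 values shown sit.

Going by these compounds, it remains open whether a 3-bromophenyl or a 4-(trifluoromethyl)phenyl group on the same carbon would separate the choice of group from its place on the ring. Also open, on these data alone, is how a ring bearing an amine or a carboxylic acid would read out here.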